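Reversing a ring-amine swap on a piperazine-bearing sulfonamide

The source may report more compounds than this note shows. Statements on the series, on what has been measured and on what is new or still open speak of the compounds shown alone.

Measured compounds:
- compound 1, `COc1cc(C)c(S(=O)(=O)N(C)CCOCC(=O)N2CCN([C@@H]3CN4CCC3CC4)CC2)c(C)c1`: 57%
- compound 2, `CCN(CC)CCN1CCN(C(=O)COCCN(C)S(=O)(=O)c2c(C)cc(OC)cc2C)CC1`: 73%
- compound 3, `Cc1c(Cl)ccc(S(=O)(=O)N(C)CC(=O)NCC(=O)N(C)Cc2ccc(C3=NCCN3)cc2)c1Cl`: 2%

In an ADME assay on microsomes from liver (Homo sapiens) for metabolic stability, with a stated time of 30 min, tested at 1 uM (a higher number here means that more of the compound is left, a lower number that less of the compound is left), compound 2 stands highest of the three; compound 1 lies nearest, and compound 3 furthest below it. Compound 4, `COc1cc(C)c(S(=O)(=O)N(C)CCOCC(=O)N2CCN([C@H]3CN4CCC3CC4)CC2)c(C)c1`, has not yet been measured. It differs from compound 2 in one place: a group of 8 heavy atoms (7 carbon, 1 nitrogen; 2 six-membered non-aromatic rings with 1 hetero atom each) in place of a group of 7 heavy atoms (6 carbon, 1 nitrogen; no ring), on an amine nitrogen in a ring. Among the measured compounds shown here, the group that enters is the one compound 1 carries, now with its 1 defined stereocentre set the other way.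

For the measured compounds named here, only one measured step bears on this change. Going from compound 1 to compound 2 removed the bicyclic group and installed the 2-(diethylamino)ethyl group, and the reading rose: a number 16 percentage points higher from compound 1 to compound 2 (beyond the scatter). The step from compound 2 to compound 4 undoes that exchange, so a fall of about the same size is expected, with the stereocentre as the only open point. For compound 4 the expected step is a number 18 percentage points lower from compound 2 to compound 4 (beyond the scatter). Compound 4 is therefore estimated at 55%, within a range from 42% to 68%.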

Compound 4, percent of the compound remaining: 26%
Beside the measured number, compound 4's estimate is 29 percentage points above it; the measured number lies below the stated range.
By their numbers in this assay, from the lowest: compound 3; then compound 4; then compound 1; then compound 2.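

Placing the bicyclic group on the amine nitrogen in place of 2-(diethylamino)ethyl proves far more costly in this assay with this configuration: a number 47 percentage points lower from compound 2 to compound 4 (beyond the scatter). With the same atoms and bonds, setting the stereocentre at the saturated ring carbon the other way gives a number 31 percentage points lower from compound 1 to compound 4 (beyond the scatter), so the size of this exchange depends on the configuration and not on the bicyclic group's atoms alone. The only difference recorded for that pair is a drawn one: the fact that one of compounds 1 and 4 is drawn with a defined configuration and the other without, at the place where they differ

The compounds shown leave open whether configuration matters to the same degree with other groups on this nitrogen, such as a chiral open-chain amine. They also leave open whether a shorter chain such as 2-(dimethylamino)ethyl or a longer diethylamino chain would hold the reading of compound 2.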